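This account rests on a few compounds, and the source may have more. Where it says the series, first, only, none or still open, it means among the compounds named here.

Three compounds of the shared core have been examined in an ADME assay on Vero cells (Chlorocebus sabaeus) for cytotoxicity, read by XTT assay, with a stated time of 72 h; a higher number here means that more compound is tolerated, a lower number that less compound is tolerated. Compound 1 `CC1=C(C(=O)Nc2ccccc2Cl)C(c2ccccc2Cl)NC(=S)N1` is the only one with a numerical entry. In this assay compound 1 gives > 100000 nM, which is a limit of the assay rather than a number. Compound 1 sits at the limit of > 100000 nM in this assay, at which 1 of the 3 values shown sits. Compound 2 `CC1=C(C(=O)Nc2ccccc2Cl)C(c2ccccc2Cl)NC(=O)N1` is recorded in this assay as "non-toxic" (no number reported), without a number. Compound 3 `CC1=C(C(=O)Nc2ccccc2Cl)C(c2ccc(Cl)cc2)NC(=O)N1` is likewise recorded in this assay as "non-toxic" (no number reported), again without a number. For the measured compounds named here, compound 3 thus stands among entries none of which gives a single value: one is a limit and the other carries no number at all, so no step between measured compounds can be drawn.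

Compound 4 `CC1=C(C(=O)Nc2ccccc2Cl)C(c2ccccc2Br)NC(=O)N1` is not yet measured. It differs from compound 3 in one place: 2-bromophenyl in place of 4-chlorophenyl on a saturated ring carbon. With the three measured compounds all tolerated up to the limit or simply recorded as non-toxic, a step in this assay from compound 3 to compound 4 beyond the scatter is not expected in either direction. Compound 4 is therefore estimated to give 100000 nM in this assay , with a range from 50000 nM to 200000 nM, and most likely only a limit will be reported.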

Compound 4, half-maximal cytotoxic concentration: > 100000 nM
Compound 4 gave a limit, no number; the forecaster's own chance of this, stated with the estimate: 80%; the middle value lies on the limit itself.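

In this assay compound 4 gives > 100000 nM, which is a limit of the assay and not a number. For the compounds shown here, compound 3 carries no number, so no step between compound 3 and compound 4 can be read. The compounds shown leave open whether the 2-bromophenyl and 4-chlorophenyl groups differ in cytotoxicity at all, as the values end at a ceiling: the limit of > 100000 nM in this assay, at which 2 of the 4 values shown sit.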